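Swapping the Benzyl Group on a Triazole Amide

The source may report more compounds than this note shows. Statements on the series, on what has been measured and on what is new or still open speak of the compounds shown alone.

Compound 1 `O=C(NCc1cn(Cc2ccc(C(F)(F)F)cc2)nn1)c1cn(-c2ccccc2)nc1-c1ccccc1` and compound 2 `O=C(NCc1cn(Cc2ccc(C(F)(F)F)cc2)nn1)c1cn(-c2ccccc2)nc1-c1ccc(F)cc1` share one core and differ only at one aromatic carbon. In a functional assay on HeLa cells (Homo sapiens) for antiproliferative activity, read by sulforhodamine B assay, with a stated time of 48 h (on this read-out lower numbers stand for stronger inhibition of growth and higher numbers for weaker inhibition of growth), compound 1 gives 1600 nM, while compound 2 gives 250 nM. Going by the values given here, the step of a 6.4-fold lower number from compound 1 to compound 2 (0.81 log units; beyond the scatter) is the only measured change so far, and it leaves compound 2 as the lower of the two numbers.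

Compound 3 `COc1cc(Cn2cc(CNC(=O)c3cn(-c4ccccc4)nc3-c3ccc(F)cc3)nn2)cc(OC)c1` keeps the fluorine of compound 2 and alters a different part of the molecule: 3,5-dimethoxyphenyl in place of 4-(trifluoromethyl)phenyl on a saturated chain carbon bound to an aromatic nitrogen. Among the compounds with values here, no measured step touches this position; the one step on record, a 6.4-fold lower number from compound 1 to compound 2 (0.81 log units; beyond the scatter), concerns the fluorine on the other side of the core and says nothing about the benzyl group. With no comparable change to lean on, the expectation is that compound 3 stays near compound 2, with a step of a 1.8-fold higher number from compound 2 to compound 3 (0.26 log units; within the scatter) anticipated but not well anchored. Compound 3 is therefore estimated to give 450 nM in this assay, within a wide range from 120 nM to 2000 nM.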

Compound 3, concentration for 50% growth inhibition: 360 nM
Compound 3: middle estimate off by 1.3-fold (0.10 log units), on the high side; the range from low to high includes it.
By their numbers in this assay, from the lowest: compounds 2 and 3 (each within the scatter of the next); then compound 1.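

Read in this assay, the swap of 4-(trifluoromethyl)phenyl for 3,5-dimethoxyphenyl gives a 1.4-fold higher number from compound 2 to compound 3 (0.16 log units; within the scatter) and is the first measured change at this position. The two groups therefore cannot be told apart by this read-out, even though they share a heavy-atom count and a carbon-only aromatic ring but differ in their atoms, with hydrogen-bond acceptors present only in 3,5-dimethoxyphenyl. No measurement here explains why the swap leaves the numbers within the scatter of each other.

On these data alone, this single pair comes from the fluorinated series, so it remains open whether the same swap would behave alike on the core of compound 1, which has hydrogen where compound 2 has fluorine. Also open, as far as these compounds go, is how far this position's latitude extends, for example to a benzyl group carrying an amine or a carboxylic acid, or to a longer chain ending in the same aromatic ring.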